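A Phenyl Swap on the Shared Core

The source may hold more compounds than are shown below. What is called first, only, known or untested is meant among the compounds shown, and "the series" means these compounds.

In a physicochemical assay for solubility, in phosphate buffer, measured as kinetic solubility, at pH 7.4 (a higher number here means a more soluble compound, a lower number a less soluble compound), compound 3 `COc1cccc(F)c1-c1nc(CN2CCC(C(=O)NCCCN3C[C@H](C)C[C@H](C)C3)CC2)c(C)o1` gives > 74 ug/mL, which is a limit and not a number. Compound 1 `Cc1oc(-c2c(Cl)cccc2Cl)nc1CN1CCC(C(=O)NCCCN2C[C@H](C)C[C@H](C)C2)CC1` also gives a limit, > 77 ug/mL. Compound 2 `Cc1cccc(-c2nc(CN3CCC(C(=O)NCCCN4C[C@H](C)C[C@H](C)C4)CC3)c(C)o2)c1` gives a limit too, > 69 ug/mL. Compound 4 `COc1ccc(-c2nc(CN3CCC(C(=O)NCCCN4C[C@H](C)C[C@H](C)C4)CC3)c(C)o2)cc1OC` carries 3,4-dimethoxyphenyl in place of 2-fluoro-6-methoxyphenyl on an aromatic carbon of the shared core: 3,4-dimethoxyphenyl in place of 2-fluoro-6-methoxyphenyl on an aromatic carbon. Three measured steps change this same group: a step that the two limits leave unreadable from compound 1 to compound 2, a step that the two limits leave unreadable from compound 1 to compound 3 and a step that the two limits leave unreadable from compound 2 to compound 3. None of them has a readable size, and none gives a direction. No change beyond the scatter is therefore expected in this assay, and the expected step is a step that the limit leaves unreadable from compound 3 to compound 4. Compound 4 is estimated at 76 ug/mL, within an expected range of 45 ug/mL to 100 ug/mL.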

Compound 4, solubility: > 76 ug/mL
Compound 4 was reported as a limit (the forecaster's own chance of this, stated with the estimate: 85%); the middle value sits exactly at the limit.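

In this assay, going by these compounds alone, compound 4 gives > 76 ug/mL, a limit, so no step to it from compound 1, compound 2 or compound 3 can be read. The compounds shown leave open whether these phenyl groups differ at all in this assay.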